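The compounds below may be only part of what the source reports. "The series", "measured", "known", "first", "only" and "open" are said of these compounds alone.

Compound 3 `CCCCCCCc1nc(-c2ccc([C@H](CC)NC(=O)[C@H]3NCC[C@@H]3O)cc2)no1` stands lowest of the three numbers measured in an assay on isolated protein for inhibition of sphingosine kinase 1 (Homo sapiens); on this read-out higher numbers stand for weaker inhibition and lower numbers for stronger inhibition: compound 3 gives 30 nM. Its nearest neighbour is compound 2 `CCCCCCCc1nc(-c2ccc([C@@H](NC(=O)[C@H]3NCC[C@@H]3O)C(C)C)cc2)no1`, for which this assay gives 110 nM, and the furthest is compound 1 `CCCCCCCc1nc(-c2ccc([C@@H](C)NC(=O)[C@H]3NCC[C@@H]3O)cc2)no1`, for which this assay gives 3800 nM. Among the measured compounds shown here, the one step between measured compounds that differ in a single place, a 3.7-fold lower number from compound 2 to compound 3 (0.56 log units; beyond the scatter), trimmed the branch on the chain carbon and lowered the number.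

Compound 4 `CCCCCCCc1nc(-c2ccc([C@H](C)NC(=O)[C@H]3NCC[C@@H]3O)cc2)no1` is the next cut in the same direction: hydrogen in place of methyl on a saturated chain carbon, two bonds along the chain from an amide-type nitrogen and an aromatic carbon. The same difference, read one bond further out, is ethyl to methyl. The step from compound 2 to compound 3 is the only one that bears on it, and it was modest but beyond the scatter, so a further trimming might be expected to move the number little or again downward. Against that, compound 1 also carries a methyl rather than an ethyl at this carbon, and its number in this assay is far higher than that of compound 3, which leaves the outcome uncertain. On balance compound 4 is expected to land a 2.0-fold higher number from compound 3 to compound 4 (0.30 log units; within the scatter), within the scatter or a little above, and its estimated value in this assay is 60 nM, with a range from 12 nM to 500 nM.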

Compound 4, half-maximal inhibitory concentration in the sphingosine kinase 1 assay: 48 nM
Estimate against measurement, compound 4: 1.3-fold (0.10 log units) above; measured number inside the range.
By their numbers in the sphingosine kinase 1 assay, from the lowest: compounds 3 and 4 (each within the scatter of the next); then compound 2; then compound 1.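

In the sphingosine kinase 1 assay, the change from ethyl to methyl on this saturated chain carbon gives a 1.6-fold higher number from compound 3 to compound 4 (0.20 log units; within the scatter), whereas the change from isopropyl to methyl gives a 2.3-fold lower number from compound 2 to compound 4 (0.36 log units; beyond the scatter), so among these three groups the isopropyl alone stands apart on this read-out. The large step of a 79-fold lower number from compound 1 to compound 4 (1.90 log units; beyond the scatter) keeps the methyl in both compounds, so it goes with the configuration at this carbon rather than with the group itself: the fact that compounds 1 and 4 differ only in the configuration as drawn. The change from ethyl to methyl also registers in a physicochemical assay for solubility, at pH 7.4 (a higher number here means a more soluble compound, a lower number a less soluble compound), where it produces a difference beyond the scatter, although it produced none in the inhibition read-out: the measured solubility of compound 3, 9 ug/mL, and of compound 4, 27 ug/mL, a 3.0-fold higher number (0.48 log units; beyond the scatter). In the physicochemical assay compound 3 gives 9 ug/mL and compound 4 gives 27 ug/mL.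

On these data alone, it remains open how an ethyl or an isopropyl would behave with the opposite configuration at this carbon, since the configuration has been compared only with the methyl. As far as these compounds go, it is also open whether a hydroxymethyl or a cyclopropyl at this carbon would keep the number in the sphingosine kinase 1 assay close to those of compound 3 and compound 4, and whether either would shift the number in the physicochemical assay as the methyl does.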